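Chloro in place of methoxy on the aryl ether

The compounds below may be only part of what the source reports. "The series", "measured", "known", "first", "only" and "open" are said of these compounds alone.

Compound 2 `COc1ccc(Oc2ccc3nncn3n2)cc1` carries a methoxy on an aromatic carbon para to a large group. In a functional assay on the whole organism with Mus musculus as the target (on this read-out lower numbers stand for an effect already at smaller amounts and higher numbers for an effect only at larger amounts of compound), compound 2 gives only a limit, > 100 mg/kg, which is the limit of > 100 mg/kg in this assay, at which 1 of the 3 values shown sits. Compound 1 `CCCCCCOc1ccc2nncn2n1` gives 32.9 mg/kg in this assay, and compound 3 `Clc1cccc(Oc2ccc3nncn3n2)c1` gives 39.4 mg/kg. Compound 4 `Clc1ccc(Oc2ccc3nncn3n2)cc1` awaits measurement; it differs from compound 2 by chloro in place of methoxy on an aromatic carbon. For the measured compounds named here, no measured pair isolates this change. Compound 3 reaches 39.4 mg/kg with a chloro on the same six-membered ring. On that basis the step from compound 2 to compound 4 is expected to be an at least 2.2-fold lower number from compound 2 to compound 4 (0.34 log units; beyond the scatter), toward smaller doses. Compound 4 is therefore expected to give about 45 mg/kg, in a range from 20 mg/kg to 100 mg/kg.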

Compound 4, dose for half-maximal effect: 36.7 mg/kg
For compound 4 the middle estimate is 1.2-fold (0.09 log units) above the measured one, within the range that was stated.
By their numbers in this assay, from the lowest: compounds 1, 4 and 3 (each within the scatter of the next). At a limit, above all of these: compound 2.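

For the compounds shown here, for chloro in place of methoxy on an aromatic carbon para to a large group, this assay shows an at least 2.7-fold lower number from compound 2 to compound 4 (0.43 log units; beyond the scatter) as the first step that isolates this change. Compound 4 gives 36.7 mg/kg and compound 3 gives 39.4 mg/kg within the scatter of each other. Compound 2 stands at a limit, so the step is a bound only: the limit of > 100 mg/kg in this assay, at which 1 of the 4 values shown sits.

The compounds shown leave open how far compound 2 truly lies from compound 4. They also leave open how an amine or a carboxylic acid on this aromatic carbon would read.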